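The source may hold more compounds than are shown below. What is called first, only, known or untested is meant among the compounds shown, and "the series" means these compounds.

Within the data shown here, compound 1 `COc1ccc(/C=N/NC(=O)Nc2ccc(Oc3ccnc(-c4nncn4CCN(C)C)c3)c(F)c2)c(OC)c1OC` is the weaker of the two compounds measured so far in a functional assay on NCI-H460 cells (Homo sapiens) for cytotoxicity, read by MTT assay, with a stated time of 72 h (a higher number here means a weaker inhibitor, a lower number a stronger inhibitor), where compound 1 gives 1790 nM. Compound 2 `CN(C)CCn1cnnc1-c1cc(Oc2ccc(NC(=O)N/N=C/c3ccc(Cl)cc3)cc2F)ccn1` gives 320 nM in this assay, a step of a 5.6-fold lower number from compound 1 to compound 2 (0.75 log units; beyond the scatter) that came with 4-chlorophenyl in place of 2,3,4-trimethoxyphenyl. Compound 3 `COc1ccc(/C=N/NC(=O)Nc2ccc(Oc3ccnc(-c4nncn4CCN(C)C)c3)c(F)c2)cc1O` differs from compound 1 at the same place, (3-hydroxy-4-methoxyphenyl in place of 2,3,4-trimethoxyphenyl on a carbon with a double bond to nitrogen). That single step shows that swapping this phenyl can shift the number, but the entering group there was different, so only a modest change is expected here, a 1.6-fold lower number from compound 1 to compound 3 (0.21 log units; within the scatter). Compound 3 is therefore estimated at 1100 nM, within 400 nM to 3500 nM.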

Compound 3, half-maximal inhibitory concentration: 620 nM
Compound 3: middle estimate off by 1.8-fold (0.25 log units), on the high side; low and high end bracket the measured number.
By their numbers in this assay, from the lowest: compounds 2 and 3 (each within the scatter of the next); then compound 1.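

With a 2.9-fold lower number from compound 1 to compound 3 (0.46 log units; beyond the scatter) in this assay, 3-hydroxy-4-methoxyphenyl also moves the number beyond the scatter, so 4-chlorophenyl is not the only replacement for 2,3,4-trimethoxyphenyl that does so. With a 1.9-fold higher number from compound 2 to compound 3 (0.29 log units; within the scatter) separating them, the 3-hydroxy-4-methoxyphenyl and 4-chlorophenyl groups cannot be told apart here. Nothing measured explains these shifts. The new group both adds a hydroxy group and loses methoxy groups, and the compounds shown do not separate these two changes. Also open, from the compounds shown here alone, is how a phenyl carrying an amine or a carboxylic acid would behave at this place.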